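Chloro in place of dimethylamino: a further limit expected

This account rests on a few compounds, and the source may have more. Where it says the series, first, only, none or still open, it means among the compounds named here.

Measured compounds:
compound 1, `CC1=CC[C@H](C(C)(C)N=C=S)CC1`: > 100000 nM, a limit of the assay
compound 2, `CC1=CC[C@H](C(C)(C)NC(=S)NN)CC1`: > 100000 nM, a limit of the assay
compound 3, `CC1=CC[C@H](C(C)(C)NC(=S)N/N=C/c2ccc(N(C)C)cc2)CC1`: > 100000 nM, a limit of the assay

In a functional assay on K562 cells (Homo sapiens) for inhibition, read by sulforhodamine B assay, with a stated time of 48 h (on this read-out lower numbers stand for stronger inhibition of growth and higher numbers for weaker inhibition of growth), none of the three reaches a number. Going by the values given here, the only step between neighbours, a step that the two limits leave unreadable from compound 1 to compound 2, is therefore unreadable. Compound 3 stands where every value shown sits, at the limit of > 100000 nM in this assay, at which 3 of the 3 values shown sit.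

Compound 4, `CC1=CC[C@H](C(C)(C)NC(=S)N/N=C/c2ccc(Cl)cc2)CC1`, differs from compound 3 by chloro in place of dimethylamino on an aromatic carbon. No measured step touches this part of the molecule, so nothing shown bears on its size. Given the limit of > 100000 nM in this assay, at which 3 of the 3 values shown sit, for compound 3, compound 4 is expected to remain at the assay limit as well, a step of a number no higher from compound 3 to compound 4 (the limit leaves the size open). The estimate for compound 4 is 100000 nM, within 30000 nM to 300000 nM.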

Compound 4, concentration for total growth inhibition: 16900 nM
Compound 4: the middle estimate sits 5.9-fold (0.77 log units) above what was measured, and the stated range ends above it.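

In this assay, chloro in place of dimethylamino on the aromatic carbon gives an at least 5.9-fold lower number from compound 3 to compound 4 (0.77 log units; beyond the scatter), so this position, para to a large group, is the first place shown where a change moves the read-out. Going by these compounds, the value for compound 3 is a limit, so the full size of the step stays open. Compound 4 alone reaches a number: the limit of > 100000 nM in this assay, at which 3 of the 4 values shown sit.

On these data alone, it remains open whether chloro itself matters or only the loss of dimethylamino. A fluoro, methoxy or nitro group at this carbon, or a bare hydrogen, could tell these apart.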